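Swapping the trimethoxyphenyl arm for a chlorophenyl

The compounds below may be only part of what the source reports. "The series", "measured", "known", "first", "only" and "open" are said of these compounds alone.

Compound 1 `COc1cc(-c2nc(SCc3cn(CC(=O)NC(=O)Nc4ccccn4)nn3)nc(Nc3ccc(C(C)C)cc3)c2C#N)cc(OC)c1OC` gives in a functional assay on MGC-803 cells (Homo sapiens) for inhibition, read by MTT assay, with a stated time of 72 h (on this read-out lower numbers stand for stronger inhibition and higher numbers for weaker inhibition), a value of 35500 nM, the highest of the three numbers measured. Compound 2 `COc1cc(-c2nc(SCc3cn(CC(=O)NC(=O)Nc4ccccn4)nn3)nc(Nc3ccc(C)cc3)c2C#N)cc(OC)c1OC` gives 7030 nM, and compound 3 `COc1cc(-c2nc(SCc3cn(CC(=O)NC(=O)Nc4ccccn4)nn3)nc(Nc3ccc(Cl)cc3)c2C#N)cc(OC)c1OC` gives 17500 nM. The measured steps, a 5.0-fold lower number from compound 1 to compound 2 (0.70 log units; beyond the scatter), a 2.0-fold lower number from compound 1 to compound 3 (0.31 log units; beyond the scatter) and a 2.5-fold higher number from compound 2 to compound 3 (0.40 log units; beyond the scatter), all concern the (4-isopropylphenyl)amino group, which compound 4 keeps. Compound 4 `CC(C)c1ccc(Nc2nc(SCc3cn(CC(=O)NC(=O)Nc4ccccn4)nn3)nc(-c3ccc(Cl)cc3)c2C#N)cc1` differs from compound 1 at another place: 4-chlorophenyl in place of 3,4,5-trimethoxyphenyl on an aromatic carbon. Among the measured compounds shown here, no measured step touches this part of the shared core, so the three steps give no guide to direction or size, and the forecast rests on compound 1 alone. For compound 4 the expected step is a 1.2-fold lower number from compound 1 to compound 4 (0.07 log units; within the scatter), within the scatter. Compound 4 is estimated at 30000 nM, expected to lie between 8000 nM and 120000 nM.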

Compound 4, half-maximal inhibitory concentration: 16900 nM
For compound 4 the middle estimate is 1.8-fold (0.25 log units) above the measured one; low and high end bracket the measured number.
By their numbers in this assay, from the lowest: compound 2; then compounds 4 and 3 (each within the scatter of the next); then compound 1.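

The earlier steps shown here changed only the (4-isopropylphenyl)amino group; this one shows that the aryl group on the shared core also matters in this assay, with a 2.1-fold lower number from compound 1 to compound 4 (0.32 log units; beyond the scatter). The 3,4,5-trimethoxyphenyl group is therefore not required for this level of inhibition, and the smaller 4-chlorophenyl, with no hydrogen-bond acceptors, does modestly better. No measurement here explains this difference.

Going by these compounds, whether the step comes from losing the methoxy groups or gaining the chlorine stays open, since a plain phenyl or 4-methoxyphenyl would be needed to separate them. On these data alone, whether the swap acts the same way alongside the other amino groups is also open.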